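The source may hold more compounds than are shown below. What is called first, only, known or untested is meant among the compounds shown, and "the series" means these compounds.

- Compound 1 `N#C[C@]1(CO)O[C@@H](n2ccc(N)nc2=O)C[C@@H]1O`: > 350000 nM
- Compound 2 `CC[C@]1(CO)O[C@@H](n2ccc(N)nc2=O)C[C@@H]1O`: > 350000 nM

Both entries from a functional assay on KB cells (Homo sapiens) for cytotoxicity (on this read-out higher numbers stand for weaker inhibition and lower numbers for stronger inhibition), are limits, not numbers: the limit of > 350000 nM in this assay, at which 2 of the 2 values shown sit. Compound 1 therefore has no exact value, only the limit > 350000 nM.

Compound 3 `N#C[C@]1(CO)O[C@@H](n2ccc(N)nc2=O)[C@H](O)[C@@H]1O` carries hydroxy in place of hydrogen on a saturated ring carbon. For the measured compounds named here, the only measured step is a step that the two limits leave unreadable from compound 1 to compound 2. It is a different change and gives no size to carry over, so no step beyond the scatter is expected in this assay. The expected step is an at least 1.1-fold lower number from compound 1 to compound 3 (0.06 log units; that floor lies within the scatter), and a reading at the same limit is quite likely. For compound 3 the estimate is 300000 nM, with an expected range of 40000 nM to 700000 nM.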

Compound 3, half-maximal inhibitory concentration: > 350000 nM
Compound 3 ended at the assay's limit (the forecaster's own chance of this, stated with the estimate: 70%); middle value at least 1.1-fold (0.06 log units) from the limit.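

Compound 1, compound 2 and compound 3 all end at a limit rather than a number, so no step between them can be read: the limit of > 350000 nM in this assay, at which 3 of the 3 values shown sit.

The compounds shown leave open how strongly any of them acts in this assay, and whether hydroxy or ethyl changes that at all.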